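The source may report more compounds than this note shows. Statements on the series, on what has been measured and on what is new or still open speak of the compounds shown alone.

Of the compounds shown here, three sharing one core have been measured so far. In a functional assay on SGC-7901 cells (Homo sapiens) for antiproliferative activity, read by MTT assay, with a stated time of 24 h (a lower number here means a stronger inhibitor, a higher number a weaker inhibitor), compound 1 `O=C(NNc1cccc(Cl)c1)c1ccc(NS(=O)(=O)c2cnc(O)nc2O)cc1` gives 11600 nM and compound 2 `O=C(NNc1cccc(Cl)c1)c1cccc(NS(=O)(=O)c2cnc(O)nc2O)c1` gives 11800 nM. Compound 3 `O=C(NNc1ccccc1F)c1cccc(NS(=O)(=O)c2cnc(O)nc2O)c1` is reported as > 20000 nM, which is a limit and not a number.

The next molecule, compound 4 `Cc1ccc(C(=O)NNC(=O)c2cccc(NS(=O)(=O)c3cnc(O)nc3O)c2)cc1`, carries (4-methylphenyl)carbonyl in place of 2-fluorophenyl on an amine nitrogen. Among the compounds with values here, only one measured step concerns that nitrogen, namely an at least 1.6-fold higher number from compound 2 to compound 3 (0.22 log units; that floor lies within the scatter), where 2-fluorophenyl stands in place of 3-chlorophenyl. That step swaps one substituted phenyl group for another, whereas compound 4 also brings in a carbonyl, so it is only a weak guide. It gives no clear direction, and no change beyond the scatter is expected in this assay. The expected size of the change is an at least 1.1-fold lower number from compound 3 to compound 4 (0.04 log units; that floor lies within the scatter). For compound 4, the estimated value is 18000 nM, with an expected range from 9000 nM to 40000 nM.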

Compound 4, half-maximal inhibitory concentration: 10100 nM
For compound 4 the middle estimate is 1.8-fold (0.25 log units) above the measured one; the measured number falls inside the stated range.
By their numbers in this assay, from the lowest: compounds 4, 1 and 2 (each within the scatter of the next). At a limit, above all of these: compound 3.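

In this assay, putting (4-methylphenyl)carbonyl in place of 3-chlorophenyl on this amine nitrogen gives a 1.2-fold lower number from compound 2 to compound 4 (0.07 log units; within the scatter), so a carbonyl can enter here with no change beyond the scatter. Putting the same group in place of 2-fluorophenyl gives an at least 1.9-fold lower number from compound 3 to compound 4 (0.29 log units; that floor lies within the scatter), which does not establish a real difference between these two compounds. That step can be read only as a floor because compound 3 is reported at a limit, not as a number: the limit of > 20000 nM in this assay, at which 1 of the 4 values shown sits.

On these data alone, it remains open whether the carbonyl or the methyl group of the new substituent has any bearing on these numbers. As far as these compounds go, it is also open whether an acetyl group, a longer chain, or an amine or carboxylic acid on the phenyl ring would move the value beyond the scatter.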